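Three Esters at the Assay Limit and a Fluorophenyl Newcomer

A few compounds are considered here, and "the series" means these few. Any claim that something is new, unique, unknown or untested is made for them only; others in the source may bear on it.

Compound 1 `COc1cc2c(c(O)c1C(=O)/C=C/c1ccc(OC(=O)c3cccc(Cl)c3)cc1)CCC(C)(C)O2` in an assay on HEK293T cells for inhibition of nuclear factor NF-kappa-B complex (Homo sapiens), read by a luciferase reporter (a lower number here means a stronger inhibitor, a higher number a weaker inhibitor), gives > 30000 nM, which is a limit of the assay rather than a number.
Compound 2 `COc1cc2c(c(O)c1C(=O)/C=C/c1ccc(OC(=O)c3cccs3)cc1)CCC(C)(C)O2` in this assay gives > 30000 nM, again a limit.
Compound 3 `COc1cc2c(c(O)c1C(=O)/C=C/c1ccc(OC(=O)c3ccc(OC(F)(F)F)cc3)cc1)CCC(C)(C)O2` in this assay gives > 30000 nM, again a limit.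

All three measured compounds share one core and differ only in the group on the carbonyl carbon. Because all three sit at the limit of > 30000 nM in this assay, at which 3 of the 3 values shown sit, none of the steps among them can be read: the step that the two limits leave unreadable from compound 1 to compound 2, the step that the two limits leave unreadable from compound 1 to compound 3 and the step that the two limits leave unreadable from compound 2 to compound 3 are all hidden by the limit. Compound 3 therefore stands at the limit alongside the other two, with no number of its own. Among the measured compounds shown here, compound 4 `COc1cc2c(c(O)c1C(=O)/C=C/c1ccc(OC(=O)c3ccccc3F)cc1)CCC(C)(C)O2` changes only this group: 2-fluorophenyl in place of 4-(trifluoromethoxy)phenyl on a carbonyl carbon. For the measured compounds named here, no measured step bears on this change with a readable size, and the three limits give no sign that any group on the carbonyl carbon has produced a measurable number. The change is expected to give no readable step beyond the scatter in this assay, so the step from compound 3 to compound 4 is estimated as a step that the limit leaves unreadable from compound 3 to compound 4. Compound 4 is therefore expected to give 40000 nM, within a range from 15000 nM to 150000 nM.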

Compound 4, half-maximal inhibitory concentration: > 30000 nM
Compound 4: a limit, no number; the forecaster's own chance of this, stated with the estimate: 85%; the middle value is on the limit's open side.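

In this assay compound 4 gives > 30000 nM, again a limit of the assay. No step from compound 1, compound 2 or compound 3 to compound 4 can be read: the limit of > 30000 nM in this assay, at which 4 of the 4 values shown sit.

The compounds shown leave open whether any group on the carbonyl carbon of the shared core gives a measurable number in this assay.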